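Phenyl for methyl on the pyrazole-like core, compound 3

This account rests on a few compounds, and the source may have more. Where it says the series, first, only, none or still open, it means among the compounds named here.

Measured so far in a functional assay on CHO-K1 cells for antagonist activity at prostaglandin D2 receptor 2 (Homo sapiens), read by scintillation counting and GTPgammaS binding, with stated times of 1 h and 2 h; a higher number here means a weaker inhibitor, a lower number a stronger inhibitor:
- compound 1, `Cc1c(CC(=O)O)c(-c2ccccc2)nn1Cc1ccc2ccccc2n1`: 870 nM
- compound 2, `Cc1nn(Cc2ccc(S(C)(=O)=O)cc2)c(C)c1CC(=O)O`: 5000 nM

Compound 2 stands at the weaker end of the two numbers: in this assay compound 2 gives 5000 nM, while compound 1 gives 870 nM, and the gap between the two is beyond the scatter. Among the measured compounds shown here, the two compounds differ in more than one place, so no single step connects them.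

Compound 3, `Cc1c(CC(=O)O)c(-c2ccccc2)nn1Cc1ccc(S(C)(=O)=O)cc1`, is not yet measured. Relative to compound 2 the change is phenyl in place of methyl on an aromatic carbon. This brings compound 3 closer to compound 1, which also carries the phenyl on the core, though the group on the ring nitrogen still differs.

For the measured compounds named here, no measured step isolates this exchange. The expectation for the step of a 3.3-fold lower number from compound 2 to compound 3 (0.52 log units; beyond the scatter) is a move towards a lower number, of moderate size. The expectation leans on compound 1, which with the phenyl in place gives 870 nM in this assay. Compound 3 is therefore estimated at 1500 nM, with a range from 400 nM to 5000 nM.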

Compound 3, half-maximal inhibitory concentration: "not active" (no number reported)
For compound 3 the study gives words and no number; the estimate stays without a comparison.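

In this assay, among the compounds shown here, compound 3 is reported as "not active" without a number, so no step from compound 2 to compound 3 can be read. No measurement shown here accounts for this result. The compounds shown leave open how far phenyl in place of methyl, taken alone, shifts the number, and what the group on the ring nitrogen contributes.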